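Working notes on a short cytotoxicity series

The source may hold more compounds than are shown below. What is called first, only, known or untested is meant among the compounds shown, and "the series" means these compounds.

Measured compounds, in a functional assay on L1210 cells (Mus musculus) for cytotoxicity; on this read-out lower numbers stand for stronger inhibition and higher numbers for weaker inhibition:

- compound 1, `COc1ccc(NC(=O)/C=C/C(=O)N2C/C(=C\c3ccc([N+](=O)[O-])cc3)C(=O)/C(=C/c3ccc([N+](=O)[O-])cc3)C2)cc1`, gives 2900 nM
- compound 2, `Cc1ccc(NC(=O)/C=C/C(=O)N2C/C(=C\c3ccc([N+](=O)[O-])cc3)C(=O)/C(=C/c3ccc([N+](=O)[O-])cc3)C2)cc1C`, gives 4900 nM
- compound 3, `Cc1ccc(NC(=O)/C=C/C(=O)N2C/C(=C\c3ccccc3)C(=O)/C(=C/c3ccccc3)C2)cc1C`, gives 31000 nM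

Compounds 1 and 2 share one core and differ only in the group on the amide-type nitrogen: 4-methoxyphenyl in place of 3,4-dimethylphenyl on an amide-type nitrogen. That change gave a 1.7-fold lower number from compound 2 to compound 1 (0.23 log units; within the scatter), so the two numbers are not separated by more than the usual spread of repeats.

Compound 3 carries the group of compound 2 on a different core. The difference between the two cores is not broken down here; what the values show is that compound 3 sits at the high end of the three numbers, with compound 2 nearest and compound 1 furthest, both separations beyond the scatter.

Compound 4, `COc1ccc(NC(=O)/C=C/C(=O)N2C/C(=C\c3ccccc3)C(=O)/C(=C/c3ccccc3)C2)cc1`, is not yet measured. It comes from compound 3 by 4-methoxyphenyl in place of 3,4-dimethylphenyl on an amide-type nitrogen. The place of the change reads the same as for the step from compound 2 to compound 1, so this is the same change, made a second time, on the core of compound 3 instead of the core of compound 1.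

For compound 4 a step of about a 1.7-fold lower number from compound 3 to compound 4 (0.24 log units; within the scatter) is expected in this assay, resting on the earlier step of the same change, a 1.7-fold lower number from compound 2 to compound 1 (0.23 log units; within the scatter), which stayed within the scatter. Compound 4 is accordingly estimated at 18000 nM, with a likely range from 7000 nM to 45000 nM.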

Compound 4, half-maximal inhibitory concentration: 6800 nM
Compound 4: middle estimate off by 2.6-fold (0.42 log units), on the high side; measured number outside the range, below it.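

In this assay, 4-methoxyphenyl in place of 3,4-dimethylphenyl on the amide-type nitrogen gave a 4.6-fold lower number from compound 3 to compound 4 (0.66 log units; beyond the scatter), a step beyond the scatter, whereas the same change on the core of compound 1 stayed within it. The change therefore cannot be carried from one core to the other as a single fixed step, since its size differed between the two cores: the same change on two cores in this assay, a 1.7-fold lower number (0.23 log units; within the scatter) from compound 2 to compound 1 and a 4.6-fold lower number (0.66 log units; beyond the scatter) from compound 3 to compound 4, 2.7-fold (0.43 log units) apart, beyond the scatter of two such steps. Within the data shown here, this rests on only two matched pairs, so it does not show why the size differs, which feature of the cores matters, or how the change would behave on any core beyond these two.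

The compounds shown leave open whether the larger step belongs to the 4-methoxyphenyl group as a whole or would also appear with a simpler group on the same nitrogen, such as 4-methylphenyl, 3,4-dimethoxyphenyl or unsubstituted phenyl. They also leave open how the step would behave on a core carrying a third kind of substituent, such as chloro or a dimethylamino group, in place of the nitro groups of compound 1 and compound 2.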